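A few compounds are considered here, and "the series" means these few. Any claim that something is new, unique, unknown or untested is made for them only; others in the source may bear on it.

In a functional assay on B16 cells (Mus musculus) for antiproliferative activity, with a stated time of 72 h (a higher number here means a weaker inhibitor, a lower number a stronger inhibitor), compound 3 (`Cc1ccc(CNc2ncnc3c2ncn3[C@@H]2O[C@H](CO)[C@@H](O)[C@H]2O)cc1`) has no number to start from: its entry reads "not determined" (no result reported). The nearest evidence comes from two related compounds. Compound 1 (`OC[C@H]1O[C@@H](n2cnc3c(NCc4ccccc4Br)ncnc32)[C@H](O)[C@@H]1O`) gives > 166000 nM, which is a limit of the assay and not a number. Compound 2 (`OC[C@H]1O[C@@H](n2cnc3c(NCc4ccc(Br)cc4)ncnc32)[C@H](O)[C@@H]1O`) gives > 166000 nM, again a limit and not a number. For compound 1 and compound 2, the common reference is therefore (the limit of > 166000 nM in this assay, at which 2 of the 3 values shown sit).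

The next compound, compound 4 (`COc1cccc(CNc2ncnc3c2ncn3[C@@H]2O[C@H](CO)[C@@H](O)[C@H]2O)c1`), differs from compound 3 by 3-methoxyphenyl in place of 4-methylphenyl on a saturated chain carbon bound to a nitrogen on an aromatic ring.

Going by the values given here, the only measured step that bears on this change is a step that the two limits leave unreadable from compound 1 to compound 2, with 4-bromophenyl in place of 2-bromophenyl at the same place. It has no readable size, so it offers no measure of how far such a change might move the result. With no value for compound 3, no step can be expected from it in either direction in this assay. Compound 4 is instead expected to sit close to the limit reached by compound 1 and compound 2, with no departure beyond the scatter.

In this assay, the expected value for compound 4 is 150000 nM, with an estimated range from 50000 nM to 320000 nM.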

Compound 4, half-maximal inhibitory concentration: > 166000 nM
Compound 4: no number, only a limit; the forecaster's own chance of this, stated with the estimate: 75%; middle value at least 1.1-fold (0.04 log units) from the limit.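

In this assay compound 4 gives > 166000 nM, which is a limit of the assay and not a number. Its steps from compound 1 and from compound 2 therefore cannot be read, as all three results are limits. The compounds shown leave open how far any of these groups on the shared core moves the result in this assay.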